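Chain lengthening on the shared core in the electroshock model

The source may hold more compounds than are shown below. What is called first, only, known or untested is meant among the compounds shown, and "the series" means these compounds.

Compound 1 `CCCCc1cccc(N2CCNCC2)n1`: 30 mg/kg
Compound 2 `CCCCCCCc1cccc(N2CCN(C)CC2)n1`: 30 mg/kg
Compound 3 `CCCCCCCc1ccnc(N2CCNCC2)c1`: 30 mg/kg

In a functional assay on the whole organism with Mus musculus as the target, in the maximal electroshock model, with a stated time of 120 min (on this read-out lower numbers stand for an effect already at smaller amounts and higher numbers for an effect only at larger amounts of compound), compound 1 gives 30 mg/kg. Compound 2 gives 30 mg/kg and compound 3 gives 30 mg/kg, both level with compound 1 at the digits shown and within the scatter, so no order can be read among the three. Compound 4 `CCCCCCCCCCc1cccc(N2CCNCC2)n1` has not yet been measured. It differs from compound 1 by hexyl in place of hydrogen on a saturated chain carbon, four bonds along the chain from an aromatic carbon. Among the compounds with values here, no step between measured compounds carries this change, so the direction of the step from compound 1 to compound 4 rests on the three equal values alone; nothing in them points beyond the scatter. The step is expected to be about no change at the digits printed from compound 1 to compound 4 (within the scatter). Compound 4 is therefore estimated at 30 mg/kg, between 15 mg/kg and 100 mg/kg.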

Compound 4, minimum effective dose: 30 mg/kg
The estimate for compound 4 equals the measured number at the digits printed; the range from low to high includes it.
By their numbers in this assay, from the lowest: compounds 1, 2, 3 and 4 (each within the scatter of the next).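

In this assay, hexyl in place of hydrogen on a saturated chain carbon, four bonds along the chain from an aromatic carbon, gives no change at the digits printed from compound 1 to compound 4 (within the scatter). Within the data shown here, this is the first measured step at this position, and it shows that this added chain of 6 carbon atoms leaves the read-out level with compound 1. Nothing on hand gives a reason for this result. The compounds shown leave open whether an amine or a carboxylic acid at the end of this chain, or a still longer chain, would read differently in this assay.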